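The source may report more compounds than this note shows. Statements on the series, on what has been measured and on what is new or still open speak of the compounds shown alone.

Working notes on the series. In an assay on isolated protein for binding affinity to prostaglandin D2 receptor (Mus musculus) (on this read-out higher numbers stand for weaker inhibition and lower numbers for stronger inhibition), compound 1 `CCCCOc1ccc(C(=O)n2c(C)c(CC(=O)O)c3cc(OC)ccc32)cc1` gives 270 nM, the lowest of the three numbers in hand. Compound 3 `CCCCOc1ccc(C(=O)n2c(C)c(CCCCC(=O)O)c3cc(OC)ccc32)cc1` gives 400 nM; the step of a 1.5-fold higher number from compound 1 to compound 3 (0.17 log units; within the scatter) stays within the scatter, so no order is read between these two. Within the data shown here, compound 2 `CCCCOc1ccc(C(=O)n2c(CCC)c(C(=O)O)c3cc(OC)ccc32)cc1` gives 1500 nM, a higher number beyond the scatter from compound 1, though compound 2 differs from compound 1 in two places and no single step is drawn for that pair.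

Compound 4 `CCCCOc1ccc(C(=O)n2c(C)c(CC(=O)O)c3cc(O)ccc32)cc1` is compound 1 with hydrogen in place of methyl on an oxygen on an aromatic ring, the methoxy read as hydroxy. Among the measured compounds shown here, none of the measured steps bears on this change: the only single step in hand, between compound 1 and compound 3, alters the chain on the core and leaves the oxygen untouched, and no measured pair differs at that oxygen. With nothing to lean on, the expected step in this assay a 1.1-fold higher number from compound 1 to compound 4 (0.05 log units; within the scatter) is taken as none beyond the scatter, in no particular direction. Compound 4 is accordingly estimated at 300 nM, with a range from 100 nM to 900 nM.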

Compound 4, inhibition constant: 1900 nM
The estimate for compound 4 lay 6.3-fold (0.80 log units) below the measured number; measured number outside the range, above it.
By their numbers in this assay, from the lowest: compounds 1 and 3 (each within the scatter of the next); then compounds 2 and 4 (each within the scatter of the next).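

In this assay, among these compounds, the methoxy to hydroxy change gives a 7.0-fold higher number from compound 1 to compound 4 (0.85 log units; beyond the scatter), the first sign that this position responds to substitution, as all the earlier compounds carry the methoxy. The methyl on an oxygen on an aromatic ring therefore counts for more here than the chain change on the core, which gave only a 1.5-fold higher number from compound 1 to compound 3 (0.17 log units; within the scatter) and stays within the scatter. Nothing in hand explains the step at this oxygen.

This single pair cannot show whether the higher number follows from the free hydroxy or from the missing methyl, and an ethoxy or a longer chain on that oxygen would separate the two readings. Going by these compounds, it also remains open how an amine or a fluorine at this place would read, and whether the step holds with the other chains on the core.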